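The source may hold more compounds than are shown below. What is called first, only, known or untested is meant among the compounds shown, and "the series" means these compounds.

Working notes on the series. Compound 1 `Cc1ccc(C(=O)n2c(-c3cn(-c4ccccc4)nc3-c3ccc(C(F)(F)F)cc3)nc3ccccc32)cc1` carries 4-methylphenyl on the carbonyl carbon, and in an ADME assay on HEK-293T cells (Homo sapiens) for cytotoxicity, read by MTT assay, with a stated time of 24 h (a lower number here means that less compound is tolerated, a higher number that more compound is tolerated), compound 1 gives 169000 nM. Compound 2 `O=C(c1ccncc1)n1c(-c2cn(-c3ccccc3)nc2-c2ccc(C(F)(F)F)cc2)nc2ccccc21` carries pyridin-4-yl at the same place, and in this assay compound 2 gives 135000 nM. Compound 3 `Cc1ccc(C(=O)n2c(-c3cn(-c4ccccc4)nc3-c3ccc(C(F)(F)F)cc3)nc3ccccc32)cn1` carries 6-methylpyridin-3-yl there, and in this assay compound 3 gives 153000 nM. Compound 3 stands within the scatter of both other members: a 1.1-fold lower number from compound 1 to compound 3 (0.04 log units; within the scatter), and a 1.1-fold higher number from compound 2 to compound 3 (0.05 log units; within the scatter). The remaining pair is likewise flat, a 1.3-fold lower number from compound 1 to compound 2 (0.10 log units; within the scatter), so none of the three aryl groups on the carbonyl carbon has set itself apart.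

Compound 4 `Cc1cncc(C(=O)n2c(-c3cn(-c4ccccc4)nc3-c3ccc(C(F)(F)F)cc3)nc3ccccc32)c1` is the next member. 5-methylpyridin-3-yl in place of 6-methylpyridin-3-yl on a carbonyl carbon The group that leaves and the group that enters have the same atoms, joined differently. Among the measured compounds shown here, the steps that bear on this change are the two into compound 3, a 1.1-fold lower number from compound 1 to compound 3 (0.04 log units; within the scatter) and a 1.1-fold higher number from compound 2 to compound 3 (0.05 log units; within the scatter), which swap whole aryl groups without moving the number beyond the scatter, and a 1.3-fold lower number from compound 1 to compound 2 (0.10 log units; within the scatter), which does the same. A rearrangement of a methyl group on a ring of this kind is a smaller change than any of those, so no step beyond the scatter is expected in either direction. Compound 4 is therefore expected to give about 150000 nM in this assay, with a range from 75000 nM to 300000 nM. The expected step, a 1.0-fold lower number from compound 3 to compound 4 (0.01 log units; within the scatter), is estimated to lie within the scatter.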

Compound 4, half-maximal cytotoxic concentration: 123000 nM
Compound 4: the middle estimate sits 1.2-fold (0.09 log units) above what was measured, and the stated range covers the measured number.
By their numbers in this assay, from the lowest: compounds 4, 2, 3 and 1 (each within the scatter of the next).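

Moving the methyl group, a change that keeps the atoms of the group the same, gives a step within the scatter in this assay (a 1.2-fold lower number from compound 3 to compound 4 (0.09 log units; within the scatter)), so 6-methylpyridin-3-yl and 5-methylpyridin-3-yl on a carbonyl carbon cannot be told apart here. The comparisons with the other two members read the same way (a 1.1-fold lower number from compound 2 to compound 4 (0.04 log units; within the scatter); a 1.4-fold lower number from compound 1 to compound 4 (0.14 log units; within the scatter)), and the last of these, though the largest step among the four compounds, still stays within the scatter, so four different aryl groups at this place now leave the number flat. No measurement at hand explains this flatness or ties it to any property of these groups.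

All four members carry a six-membered aromatic ring on the carbonyl carbon, so the compounds shown leave open whether an aliphatic amine, a carboxylic acid or a longer alkyl chain at this place would stay within the same scatter. They also leave open whether the number in this assay responds to a change elsewhere in the shared core, such as replacing the trifluoromethyl group, which is common to all four compounds.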